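The source may report more compounds than this note shows. Statements on the series, on what has been measured and on what is new or still open speak of the compounds shown alone.

Compound 1 `CC1(C)C=C(n2ccccc2=O)c2ccccc2O1` gives 5.05 in a functional assay (trachea) with Rattus norvegicus as the target; a higher number here means a more potent compound, by a factor of ten per unit of this negative logarithm, a lower number a less potent compound. Compound 2 `CC(=O)c1ccc2c(c1)C(n1ccccc1=O)=CC(C)(C)O2` gives 6.65, and compound 3 `CCC(=O)c1ccc2c(c1)C(n1ccccc1=O)=CC(C)(C)O2` gives 5.85, the second highest of the three numbers. An acetyl or propanoyl on an aromatic carbon raised the number: a number 1.60 log units higher from compound 1 to compound 2 (beyond the scatter) and a number 0.80 log units higher from compound 1 to compound 3 (beyond the scatter). A methyl on the saturated chain carbon bound to the carbonyl carbon lowered it: a number 0.80 log units lower from compound 2 to compound 3 (beyond the scatter). Compound 4 `CC1(C)C=C(n2ccccc2=O)c2cc(C(=O)c3ccccc3)ccc2O1` differs from compound 3 by phenyl in place of ethyl on a carbonyl carbon. Among the measured compounds shown here, only the step from compound 2 to compound 3 bears on enlarging the group on the carbonyl carbon, and it was modest and downward. A further modest drop in this assay is expected, with real uncertainty about direction. Compound 4 is therefore estimated at 5.5, between 4.7 and 6.3. For compound 4 the expected step is a number 0.35 log units lower from compound 3 to compound 4 (beyond the scatter).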

Compound 4, logarithm of the reciprocal of the active concentration, log(1/C): 6.21
For compound 4 the middle estimate is 0.71 log units below the measured one; low and high end bracket the measured number.
By their numbers in this assay, from the lowest: compound 1; then compound 3; then compound 4; then compound 2.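

In this assay the change from propanoyl to benzoyl gave a number 0.36 log units higher from compound 3 to compound 4 (beyond the scatter) and so ran opposite to the earlier change from acetyl to propanoyl: across these compounds the number does not fall steadily as the group on the carbonyl carbon grows. Benzoyl still falls short of acetyl, with a number 0.44 log units lower from compound 2 to compound 4 (beyond the scatter) in that comparison. Against hydrogen on the aromatic carbon, benzoyl keeps a large gain, with a number 1.16 log units higher from compound 1 to compound 4 (beyond the scatter) over that step.

Going by these compounds, whether the carbonyl itself is needed stays open, as does whether an amine or a carboxylic acid on that aromatic carbon would serve as well. No evidence at hand accounts for the reversal between the two steps.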